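A few compounds are considered here, and "the series" means these few. Any claim that something is new, unique, unknown or untested is made for them only; others in the source may bear on it.

In a functional assay on MC-38 cells (Mus musculus) for antiproliferative activity (on this read-out higher numbers stand for weaker inhibition and lower numbers for stronger inhibition), compound 1 (`COc1ccc(S(=O)(=O)Nc2cccc3c(C#N)c[nH]c23)cc1`) gives 0.17 ug/mL as its measured value. Compound 2 (`N#Cc1c[nH]c2c(NS(=O)(=O)c3ccc(C(=O)O)cc3)cccc12`) gives > 100 ug/mL as a limit of the assay and not a number. Compound 3 (`N#Cc1c[nH]c2c(NS(=O)(=O)c3ccc(C(N)=O)cc3)cccc12`) has amino in place of hydroxy on a carbonyl carbon, carboxy to carbamoyl (amino in place of hydroxy on a carbonyl carbon). Going by the values given here, the one measured step that bears on this change is large and beyond the scatter: an at least 580-fold higher number from compound 1 to compound 2 (2.76 log units; beyond the scatter) with carboxy in place of methoxy on an aromatic carbon. With the carboxy gone, part of that rise is expected to return. The expected step is an at least 33-fold lower number from compound 2 to compound 3 (1.52 log units; beyond the scatter) in this assay toward stronger inhibition. The estimate for compound 3 is 3 ug/mL (expected range 0.3 ug/mL to 40 ug/mL).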

Compound 3, half-maximal inhibitory concentration: 0.68 ug/mL
Beside the measured number, compound 3's estimate is 4.4-fold (0.64 log units) above it, and the stated range covers the measured number.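

Changing only the hydroxy of the carboxy to amino brings strong inhibition back in this assay: an at least 140-fold lower number from compound 2 to compound 3 (2.16 log units; beyond the scatter). A carbonyl group at this position is therefore compatible with activity, although carbamoyl still falls modestly short of methoxy: a 4.0-fold higher number from compound 1 to compound 3 (0.60 log units; beyond the scatter). On these data alone, the value of compound 2 is a limit of the assay and not a number, so the true size of the first step stays unknown: the limit of > 100 ug/mL in this assay, at which 1 of the 3 values shown sits.

As far as these compounds go, whether a methyl ester or an amine in this place would behave more like compound 2 or more like compound 3 remains open.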